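The source may hold more compounds than are shown below. What is called first, only, known or untested is meant among the compounds shown, and "the series" means these compounds.

Of the compounds shown here, three have been measured in an assay on a protein complex for inhibition of CDK8/Cyclin C (Homo sapiens), with a stated time of 1 h; a higher number here means a weaker inhibitor, a lower number a stronger inhibitor. Compound 1 `CNC(=O)/C=C/c1ccncc1-c1ccc2cc[nH]c2c1` gives 18.6 nM. Compound 2 `O=C(/C=C/c1ccncc1-c1ccc2cc[nH]c2c1)N1CCOCC1` gives 43.9 nM. Compound 3 `O=C(CCc1ccncc1-c1ccc2ccccc2c1)N1CCOCC1` gives 45.5 nM, and compounds 2 and 3 lie within the scatter of each other, so no order between them can be read.

Compounds 1 and 2 share a core and differ in a single place: methylamino in place of morpholin-4-yl on a carbonyl carbon. That change produced a 2.4-fold lower number from compound 2 to compound 1 (0.37 log units; beyond the scatter).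

Compound 4 `CNC(=O)CCc1ccncc1-c1ccc2ccccc2c1` has not yet been measured. It stands to compound 3 as compound 1 stands to compound 2: methylamino in place of morpholin-4-yl on a carbonyl carbon. The two cores differ, and the difference between the core of compound 2 and the core of compound 3 is not broken down here. The surroundings of the change also differ slightly in the two pairs: in the first pair the carbonyl carbon's other neighbour is a double-bonded chain carbon, in the second it is a saturated chain carbon, so this is the same kind of change rather than the same change.

Because compound 2 gives 43.9 nM and compound 3 gives 45.5 nM, the two starting points sit at nearly the same value. Because the earlier change gave a 2.4-fold lower number from compound 2 to compound 1 (0.37 log units; beyond the scatter), a step of similar size is expected here, estimated as a 2.1-fold lower number from compound 3 to compound 4 (0.32 log units; beyond the scatter). On that basis compound 4 is expected to give about 22 nM, with a plausible range from 10 nM to 50 nM.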

Compound 4, half-maximal inhibitory concentration: 21.1 nM
For compound 4 the middle estimate is 1.0-fold (0.02 log units) above the measured one; the measured number falls inside the stated range.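

In this assay, putting methylamino in place of morpholin-4-yl on a carbonyl carbon gave a 2.2-fold lower number from compound 3 to compound 4 (0.33 log units; beyond the scatter). Set beside the earlier case, the step keeps its direction and its size cannot be told apart on the two cores: the same change on two cores in this assay, a 2.4-fold lower number (0.37 log units; beyond the scatter) from compound 2 to compound 1 and a 2.2-fold lower number (0.33 log units; beyond the scatter) from compound 3 to compound 4, 1.1-fold (0.04 log units) apart, within the scatter of two such steps. This shows that the change carried over in these two pairs, even though the carbonyl carbon's other neighbour is a double-bonded chain carbon in one pair and a saturated chain carbon in the other, but two pairs do not make a rule for every core in the series, and the numbers alone do not explain why the step has this size.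

The compounds shown leave open whether the lower number goes with the amide hydrogen that methylamino carries or with the loss of the morpholine ring, a question that a dimethylamino or a piperidin-1-yl group on the same carbonyl carbon could help to separate. Also open, as far as these compounds go, is how the core of compound 1 would behave with a saturated chain, and the core of compound 3 with a double-bonded one, since those pairings would show the effect of each part of the core on its own.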